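A pyridinium ring in place of a hydroxyphenyl

This account rests on a few compounds, and the source may have more. Where it says the series, first, only, none or still open, it means among the compounds named here.

Among the measured compounds shown here, compound 1 `C[N+](C)(C)Cc1cn(Cc2cccc(O)c2)c2ccccc12` gives 14700 nM in an assay on HEK293 cells for antagonist activity at Neuronal acetylcholine receptor; alpha4/beta2 (Homo sapiens), read by calcium flux (on this read-out higher numbers stand for weaker inhibition and lower numbers for stronger inhibition), the higher of the two numbers measured so far. Compound 2 `COc1ccc(Cn2cc(C[N+](C)(C)C)c3ccccc32)cc1O` gives 9500 nM in this assay, and the step of a 1.5-fold lower number from compound 1 to compound 2 (0.19 log units; within the scatter) changes nothing beyond the scatter. Compound 3 `C[n+]1cccc(Cn2cc(C[N+](C)(C)C)c3ccccc32)c1` differs from compound 1 by a group of 7 heavy atoms (6 carbon, 1 nitrogen; one six-membered aromatic ring with 1 hetero atom) in place of a group of 7 heavy atoms (6 carbon, 1 oxygen; one six-membered aromatic ring of carbon only), on a saturated chain carbon bound to an aromatic nitrogen. For the measured compounds named here, no measured step bears on this exchange; the only known step concerns a different part of the molecule. The step of a 1.2-fold lower number from compound 1 to compound 3 (0.09 log units; within the scatter) is therefore expected to stay within the scatter. Compound 3 is estimated at 12000 nM, with a range from 3000 nM to 45000 nM.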

Compound 3, half-maximal inhibitory concentration: > 100000 nM
Compound 3: only a limit was reported; the forecaster's own chance of this, stated with the estimate: 20%; middle value at least 8.3-fold (0.92 log units) from the limit.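

Replacing the 3-hydroxyphenyl with the ring carrying a net charge of +1, on a saturated chain carbon bound to an aromatic nitrogen, gives an at least 6.8-fold higher number from compound 1 to compound 3 (0.83 log units; beyond the scatter). Among the compounds shown here, this is the first step here beyond the scatter, so this place on the core of compound 1 does respond to change. Compound 3 gives only a limit in this assay: the limit of > 100000 nM in this assay, at which 1 of the 3 values shown sits.

The exchange removes the hydroxyl and adds the charge in a single change, so the compounds shown cannot tell which of the two matters. A plain pyridine ring or an unsubstituted phenyl at this place would help to separate them.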